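The source may hold more compounds than are shown below. What is called first, only, known or untested is meant among the compounds shown, and "the series" means these compounds.

Of the compounds shown here, three have been measured in an ADME assay on microsomes from liver (Homo sapiens) for metabolic stability, tested at 2.5 uM; a higher number here means faster removal of the compound, a lower number slower removal. Compound 1 `COc1ccc(-c2c(S(=O)(=O)c3cccc(F)c3)cnc3c(F)cccc23)cc1` gives 2.48 mL/min, and compound 3 `COc1ccc(-c2c(S(=O)(=O)c3ccc(F)c(F)c3)cnc3c(F)cccc23)cc1` gives 2.12 mL/min. Compound 2 `O=S(=O)(c1ccc(F)c(F)c1)c1cnc2cc(F)ccc2c1-c1cccc(F)c1` gives 0.6 mL/min, the lowest of the three; the difference between the core of compound 2 and the core of compound 3 is not broken down here. Compound 4 `O=S(=O)(c1cccc(F)c1)c1cnc2cc(F)ccc2c1-c1cccc(F)c1` has not yet been measured. Compound 4 differs from compound 2 by hydrogen in place of fluoro on an aromatic carbon, and compound 1 differs from compound 3 by the same change, (hydrogen in place of fluoro on an aromatic carbon). Between those two measured compounds, this change gave a 1.2-fold higher number from compound 3 to compound 1 (0.07 log units; within the scatter). The expected step is a 1.2-fold higher number from compound 2 to compound 4 (0.07 log units; within the scatter), because the same change gave a 1.2-fold higher number from compound 3 to compound 1 (0.07 log units; within the scatter). Compound 4 is therefore estimated at 0.7 mL/min, with a likely range from 0.35 mL/min to 1.4 mL/min.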

Compound 4, intrinsic clearance in a liver preparation (reported as CLH), per the amount of preparation that the assay uses: 0.24 mL/min
Estimate against measurement, compound 4: 2.9-fold (0.46 log units) above; the whole stated range lies above it.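

In this assay, going from a 3,4-difluorophenyl to a 3-fluorophenyl group gives a 2.5-fold lower number from compound 2 to compound 4 (0.40 log units; beyond the scatter). Set beside the earlier case, the same change did not carry over unchanged from one core to the other: the same change on two cores in this assay, a 1.2-fold higher number (0.07 log units; within the scatter) from compound 3 to compound 1 and a 2.5-fold lower number (0.40 log units; beyond the scatter) from compound 2 to compound 4, 2.9-fold (0.47 log units) apart, beyond the scatter of two such steps. So in this series, a step read on one core cannot simply be transferred to the other, but two pairs do not show which feature of the cores sets the steps apart, or how the change would behave on a third core.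

The compounds shown leave open what would happen with a chloro group, an amine or a carboxylic acid in place of the fluoro that stays on this ring. They also leave open whether either of the two steps would hold for such groups.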